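Notes on the bromoanilide series: the step to compound 4

A few compounds are considered here, and "the series" means these few. Any claim that something is new, unique, unknown or untested is made for them only; others in the source may bear on it.

Measured so far:
Compound 1, `Cc1cc(Cc2ccccc2)c(=O)n(CC(=O)Nc2ccc(Br)cc2)n1`. In a functional assay on HL-60 cells (Homo sapiens), read by calcium flux (a higher number here means that more compound is needed for the effect, a lower number that less compound is needed), compound 1 gives > 50000 nM, which is a limit of the assay rather than a number.
Compound 2, `Cc1cc(Cc2ccc(C#N)cc2)c(=O)n(CC(=O)Nc2ccc(Br)cc2)n1`. In this assay compound 2 gives > 50000 nM, again a limit.
Compound 3, `Cc1cc(N)c(=O)n(CC(=O)Nc2ccc(Br)cc2)n1`. In this assay compound 3 gives > 50000 nM, also a limit.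

Compound 3 therefore stands at the same place as every other measured compound: the limit of > 50000 nM in this assay, at which 3 of the 3 values shown sit. The three steps among them, a step that the two limits leave unreadable from compound 1 to compound 2, a step that the two limits leave unreadable from compound 1 to compound 3 and a step that the two limits leave unreadable from compound 2 to compound 3, are all unreadable in size and direction; the series has not yet produced a single number.

Compound 4, `COc1ccc(Nc2cc(C)nn(CC(=O)Nc3ccc(Br)cc3)c2=O)cc1`, differs from compound 3 by 4-methoxyphenyl in place of hydrogen on a nitrogen on an aromatic ring. Going by the values given here, no measured step touches this nitrogen; the three measured steps concern the carbon that carries benzyl, 4-cyanobenzyl or amino, and none of them is readable anyway. There is thus nothing from which to read a size or direction for the step to compound 4.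

Compound 4 is expected to give 30000 nM, estimated between 3000 nM and 100000 nM. The expected step of an at least 1.6-fold lower number from compound 3 to compound 4 (0.22 log units; that floor lies within the scatter) starts from a limit and would only become readable if compound 4 returns a number in this assay.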

Compound 4, half-maximal effective concentration: > 50000 nM
Compound 4 gave a limit, no number; the forecaster's own chance of this, stated with the estimate: 60%; middle value at least 1.6-fold (0.22 log units) away from the limit.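

In this assay compound 4 gives > 50000 nM, a limit of the assay and not a number. The steps to compound 4 from compound 1, compound 2 and compound 3 therefore cannot be read. The compounds shown leave open whether any change to the shared core gives a number in this assay: the limit of > 50000 nM in this assay, at which 4 of the 4 values shown sit.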